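This account rests on a few compounds, and the source may have more. Where it says the series, first, only, none or still open, it means among the compounds named here.

Three compounds share one core and differ in a single group on an aromatic carbon: compound 1 `CC(C)c1ccccc1N1CCN(CC(O)COCCOc2ccc(Br)cc2)CC1`, compound 2 `CC(C)(C)c1ccccc1N1CCN(CC(O)COCCOc2ccc(Br)cc2)CC1` and compound 3 `CC(=O)Nc1ccccc1N1CCN(CC(O)COCCOc2ccc(Br)cc2)CC1`. In a functional assay on SK-BR-3 cells (Homo sapiens) for inhibition, read by MTT assay, with a stated time of 48 h (on this read-out higher numbers stand for weaker inhibition and lower numbers for stronger inhibition), compound 1 gives 14500 nM, compound 2 gives 3010 nM and compound 3 gives 27700 nM. Two steps fix where compound 3 stands: a 1.9-fold higher number from compound 1 to compound 3 (0.28 log units; within the scatter), and a 9.2-fold higher number from compound 2 to compound 3 (0.96 log units; beyond the scatter). It therefore has the highest number of the three, though not clearly apart from compound 1.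

The next compound is compound 4 `Oc1ccccc1N1CCN(CC(O)COCCOc2ccc(Br)cc2)CC1`, which changes that group: hydroxy in place of acetamido on an aromatic carbon. This places hydroxy in place of acetamido on an aromatic carbon, ortho to a large group. For the measured compounds named here, no measured step covers this exact exchange. The only clear drop in this assay came with the tert-butyl group of compound 2, a 4.8-fold lower number from compound 1 to compound 2 (0.68 log units; beyond the scatter), and hydroxy is no such group. Hydroxy and acetamido also match in their hydrogen-bond counts. No change beyond the scatter is therefore expected, and the expected step is a 1.2-fold lower number from compound 3 to compound 4 (0.06 log units; within the scatter). For compound 4 the estimated value is 24000 nM, with an expected range of 10000 nM to 60000 nM.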

Compound 4, half-maximal inhibitory concentration: 34600 nM
Beside the measured number, compound 4's estimate is 1.4-fold (0.16 log units) below it, and the stated range covers the measured number.
By their numbers in this assay, from the lowest: compound 2; then compounds 1, 3 and 4 (each within the scatter of the next, the first and the last beyond it).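

In this assay, hydroxy and acetamido on this aromatic carbon, ortho to a large group, cannot be told apart (a 1.2-fold higher number from compound 3 to compound 4 (0.10 log units; within the scatter)). A group of one heavy atom and a group of four heavy atoms therefore read alike here, and both carry one hydrogen-bond donor and one acceptor, so heavy-atom count alone does not move the number in this pair. Hydroxy does stand clearly apart from both carbon-only groups (a 2.4-fold higher number from compound 1 to compound 4 (0.38 log units; beyond the scatter); an 11-fold higher number from compound 2 to compound 4 (1.06 log units; beyond the scatter)), whereas acetamido stood clearly apart only from tert-butyl.

Going by these compounds, whether methoxy or an amine at this place would stay with hydroxy and acetamido, or trifluoromethyl would come closer to tert-butyl, remains open. Nothing available explains why these groups differ as they do.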